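From compound 2 to compound 3: a group exchange

This account rests on a few compounds, and the source may have more. Where it says the series, first, only, none or still open, it means among the compounds named here.

Measured in a functional assay on HepG2 cells (Homo sapiens) for antiproliferative activity, read by MTT assay, with a stated time of 72 h; on this read-out higher numbers stand for weaker inhibition and lower numbers for stronger inhibition:
compound 1 `O=C1O/C(=C\Cn2cnc3cncc(Br)c32)C(OCc2ccccc2)=C1OCc1ccccc1`: 46900 nM
compound 2 `O=C1O/C(=C\Cn2cnc3ncc(Br)c-3c2)C(OCc2ccccc2)=C1OCc1ccccc1`: > 100000 nM

Compound 2 stands only at a limit of this assay, > 100000 nM. Compound 3 `O=C1O/C(=C\Cn2cnc3c(Cl)c(F)nc(F)c32)C(OCc2ccccc2)=C1OCc1ccccc1` differs from it as follows: a group of 12 heavy atoms (6 carbon, 3 nitrogen, 2 fluorine, 1 chlorine; one five-membered aromatic ring with 2 hetero atoms, one six-membered aromatic ring with 1 hetero atom) in place of a group of 10 heavy atoms (6 carbon, 3 nitrogen, 1 bromine; one five-membered aromatic ring with 1 hetero atom, one six-membered aromatic ring with 2 hetero atoms), on a saturated chain carbon bound to a double-bonded chain carbon. Going by the values given here, the one measured step bearing on this is an at least 2.1-fold higher number from compound 1 to compound 2 (0.32 log units; beyond the scatter). The group entering compound 3 has the same ring counts as the group in compound 1, so that step may partly reverse. Among the compounds with values here, its fluorine and chlorine atoms have no measured precedent here, which keeps the expectation wide. A move to a lower number is expected, an at least 3.3-fold lower number from compound 2 to compound 3 (0.52 log units; beyond the scatter). Compound 3 is estimated at 30000 nM, within 8000 nM to 100000 nM.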

Compound 3, half-maximal inhibitory concentration: > 100000 nM
Compound 3: only a limit was reported (the forecaster's own chance of this, stated with the estimate: 25%); middle value at least 3.3-fold (0.52 log units) from the limit.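

Keeping the ring counts of compound 1 on a saturated chain carbon bound to a double-bonded chain carbon did not keep its activity: the group carrying two fluorine atoms and one chlorine atom gives an at least 2.1-fold higher number from compound 1 to compound 3 (0.32 log units; beyond the scatter). Compound 3 gives only a limit of the assay, > 100000 nM. Its step from compound 2 cannot be read, as both values are limits: the limit of > 100000 nM in this assay, at which 2 of the 3 values shown sit.

The compounds shown leave open which of the fluorine and chlorine atoms accounts for this step. They also leave open how the same ring pair would read with an amine in place of these halogens.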